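This account rests on a few compounds, and the source may have more. Where it says the series, first, only, none or still open, it means among the compounds named here.

Measured compounds:
- compound 1, `O=C(COc1cccc2ccccc12)N/N=C/c1ccc(O)cc1`: 60.6 ug/mL
- compound 2, `C/C(=N\NC(=O)COc1cccc2ccccc12)c1ccc([N+](=O)[O-])cc1`: > 100 ug/mL

For the measured compounds named here, in an ADME assay on HEL cells (Homo sapiens) for cytotoxicity (on this read-out higher numbers stand for lower toxicity in this test and lower numbers for higher toxicity in this test), compound 1 gives 60.6 ug/mL, the only plain number among the two values shown. Compound 2 gives > 100 ug/mL, which is a limit of the assay and not a number. Going by the values given here, compound 2 thus sits at the limit of > 100 ug/mL in this assay, at which 1 of the 2 values shown sits, so no step between compound 1 and compound 2 can be sized from these two values, and no pair differing in one place has been measured.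

Compound 3, `COc1ccc(/C=N/NC(=O)COc2cccc3ccccc23)cc1`, is not yet measured. It differs from compound 1 by methyl in place of hydrogen on an oxygen on an aromatic ring. The rest of the shared core of compound 1 is kept unchanged.

Among the compounds with values here, no measured step gives a precedent for this change in this assay. Given that the parent compound 1 gives 60.6 ug/mL, the step is expected to be small, in either direction, and likely within the usual scatter; the estimated step of a 1.1-fold higher number from compound 1 to compound 3 (0.03 log units; within the scatter) reflects this. Compound 3 is therefore expected to give about 65 ug/mL, with a range of 30 ug/mL to 100 ug/mL, in this assay.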

Compound 3, half-maximal cytotoxic concentration: 100 ug/mL
Estimate against measurement, compound 3: 1.5-fold (0.19 log units) below; measured number inside the range.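

In this assay, methyl in place of hydrogen on an oxygen on an aromatic ring, read as 4-hydroxyphenyl to 4-methoxyphenyl, gives a 1.7-fold higher number from compound 1 to compound 3 (0.22 log units; within the scatter). For the compounds shown here, this is the first step that can be sized between compounds differing in one place, and as it lies within the scatter, the free hydroxy and the methoxy cannot be told apart on this read-out, so this position accepts the methyl without a change that can be separated from repeat variation. Compound 2 remains a limit of the assay and not a number, and it adds no sized step: the limit of > 100 ug/mL in this assay, at which 1 of the 3 values shown sits.

From the compounds shown here alone, what an amine or a carboxylic acid in place of the hydroxy would do at this position stays open, as does the effect of a longer chain on this oxygen, such as ethyl or propyl. A single step at one place also gives no trend for the series and says nothing about changes elsewhere on the shared core.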